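A few compounds are considered here, and "the series" means these few. Any claim that something is new, unique, unknown or untested is made for them only; others in the source may bear on it.

Of the compounds shown here, two have been measured so far in an assay on isolated protein for inhibition of serine protease 1 (Homo sapiens), read by fluorescence; a higher number here means a weaker inhibitor, a lower number a stronger inhibitor. Compound 1 `CNC(=O)[C@@H]1C[C@H](N2CCc3c(cccc3OCCC3CC3)C2)CN1C(=O)c1ccc(CN)c(OC)c1` gives 2 nM and stands at the lowest number of the two; compound 2 `CNC(=O)[C@@H]1C[C@H](n2cc(C3CC3)nn2)CN1C(=O)c1ccc(CN)c(OC)c1` gives 2100 nM, a far higher number, a gap well beyond the usual scatter. Among the measured compounds shown here, no single-point step between measured compounds is available, so compound 1 and compound 2 only mark the span of the numbers seen.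

Compound 3 `CNC(=O)[C@@H]1C[C@H](N2CCc3c(cccc3OCCc3ccccc3)C2)CN1C(=O)c1ccc(CN)c(OC)c1` has not yet been measured. It differs from compound 1 in one place: phenyl in place of cyclopropyl on a saturated chain carbon, two bonds along the chain from an oxygen on an aromatic ring. The ether chain and the oxygen on the aromatic ring are kept; only the terminal ring is exchanged. For the measured compounds named here, with no measured pair showing this change, the step cannot be read from data. The expectation is a small step, within or just outside the scatter, leaning toward a slightly higher number; the estimated step is a 2.0-fold higher number from compound 1 to compound 3 (0.30 log units; within the scatter). Compound 3 is therefore estimated at 4 nM, with a range from 1 nM to 20 nM.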

Compound 3, half-maximal inhibitory concentration: 3 nM
Estimate against measurement, compound 3: 1.3-fold (0.12 log units) above; the measured number falls inside the stated range.
By their numbers in this assay, from the lowest: compounds 1 and 3 (each within the scatter of the next); then compound 2.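

In this assay, among the compounds shown here, replacing cyclopropyl with phenyl on the saturated chain carbon gives a 1.5-fold higher number from compound 1 to compound 3 (0.18 log units; within the scatter), the first single-place step. At this position, the 2-cyclopropylethoxy and phenethyloxy groups therefore cannot be told apart in this assay, even though the terminal ring grows from 3 heavy atoms to 6 and changes from a non-aromatic to an aromatic ring. No supporting information bears on this result.

Going by these compounds, it remains open whether the end of this ether chain accepts an amine, a carboxylic acid or a longer chain with the same result. Steps involving compound 2 cannot be read, as it differs from compound 1 and compound 3 in more than one place, so its higher number cannot be assigned to any single change.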